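The source may hold more compounds than are shown below. What is called first, only, known or untested is meant among the compounds shown, and "the series" means these compounds.

Measured in an ADME assay on microsomes (Homo sapiens) for metabolic stability; on this read-out lower numbers stand for slow clearance and higher numbers for fast clearance:
- compound 1 `Cc1cc(C(F)(F)F)c2cccc(OCc3c(Cl)ccc(S(=O)(=O)N4CCC[C@H]4C(=O)O)c3Cl)c2n1`: 8.33 mL/min/kg
- compound 2 `Cc1cc(C(F)(F)F)c2cccc(OCc3c(Cl)ccc(S(=O)(=O)N4CCC[C@H]4CO)c3Cl)c2n1`: 250 mL/min/kg
- compound 3 `CNC(=O)[C@@H]1CCCN1S(=O)(=O)c1ccc(Cl)c(COc2cccc3c(-c4nccn4C)cc(C)nc23)c1Cl`: 117 mL/min/kg

Compound 3 stands second highest of the three, below compound 2 and well above compound 1. Compound 4 `CNC(=O)[C@@H]1CCCN1S(=O)(=O)c1ccc(Cl)c(COc2cccc3c(-c4ccncc4)cc(C)nc23)c1Cl` carries pyridin-4-yl in place of 1-methyl-1H-imidazol-2-yl on an aromatic carbon, opposite the ring nitrogen (pyridin-4-yl in place of 1-methyl-1H-imidazol-2-yl on an aromatic carbon). Within the data shown here, the only measured step, a 30-fold higher number from compound 1 to compound 2 (1.48 log units; beyond the scatter), is large, but it swaps carboxy for hydroxymethyl on a saturated ring carbon, a different place and a different pair of groups. Among the measured compounds shown here, no measured pair tests the present swap, so neither size nor direction carries over. The expected step is a 1.1-fold lower number from compound 3 to compound 4 (0.03 log units; within the scatter), with no change beyond the scatter anticipated. For compound 4 the estimated value is 110 mL/min/kg, with an expected range of 45 mL/min/kg to 240 mL/min/kg.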

Compound 4, clearance: 217 mL/min/kg
For compound 4 the middle estimate is 2.0-fold (0.30 log units) below the measured one, and the stated range covers the measured number.
By their numbers in this assay, from the lowest: compound 1; then compounds 3, 4 and 2 (each within the scatter of the next, the first and the last beyond it).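

On an aromatic carbon opposite the ring nitrogen, pyridin-4-yl in place of 1-methyl-1H-imidazol-2-yl gives a 1.9-fold higher number from compound 3 to compound 4 (0.27 log units; within the scatter) in this assay for this swap. The five-membered and six-membered aromatic rings are therefore not told apart at this position, unlike the large step seen at the saturated ring carbon. Nothing available explains this result.

Open, from the compounds shown here alone, is whether an aminomethyl group or a carboxylic acid at this position would give a step beyond the scatter. Also open, going by these compounds, is whether the same swap stays within the scatter when the methyl amide is replaced by carboxy.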